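The source may hold more compounds than are shown below. What is called first, only, known or untested is meant among the compounds shown, and "the series" means these compounds.

Of the compounds shown here, three built on one shared core have been measured in an assay on cells for displacement of a labelled ligand from Glucagon receptor (Homo sapiens), in the presence of a further agent that is not named here; a higher number here means a weaker inhibitor, a lower number a stronger inhibitor. Compound 1 `O=C(O)CCNC(=O)c1ccc(C(Oc2ccc(-n3cc(C(F)(F)F)cn3)cc2)C2CCC2)cc1` gives 700 nM, compound 2 `CC(C)(C)C(Oc1ccc(-n2cc(C(F)(F)F)cn2)cc1)c1ccc(C(=O)NCCC(=O)O)cc1` gives 170 nM, and compound 3 `CCCC(Oc1ccc(-n2cc(C)cn2)cc1)c1ccc(C(=O)NCCC(=O)O)cc1` gives 1900 nM, the highest of the three numbers, with compound 1 nearest to it and compound 2 furthest away. Compound 4 `CCCC(Oc1ccc(-n2cc(C(F)(F)F)cn2)cc1)c1ccc(C(=O)NCCC(=O)O)cc1` differs from compound 3 by trifluoromethyl in place of methyl on an aromatic carbon. Among the compounds with values here, no measured step touches this group: the only measured step, a 4.1-fold lower number from compound 1 to compound 2 (0.61 log units; beyond the scatter), alters the group on the saturated chain carbon instead, so it does not bear directly on the change. Compounds 1 and 2 both carry the trifluoromethyl group and both sit lower than compound 3, yet each also differs from it on the saturated chain carbon, so their numbers give only indirect guidance. A modest drop is therefore expected, a 2.4-fold lower number from compound 3 to compound 4 (0.38 log units; beyond the scatter). Compound 4 is estimated at 800 nM, within a range from 300 nM to 2500 nM.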

Compound 4, inhibition constant: 890 nM
Beside the measured number, compound 4's estimate is 1.1-fold (0.05 log units) below it; measured number inside the range.
By their numbers in this assay, from the lowest: compound 2; then compounds 1 and 4 (each within the scatter of the next); then compound 3.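

Within the data shown here, putting 4-(trifluoromethyl)-1H-pyrazol-1-yl in place of 4-methyl-1H-pyrazol-1-yl gives a 2.1-fold lower number from compound 3 to compound 4 (0.33 log units; beyond the scatter) in this assay and is the first direct reading of this position. With trifluoromethyl held fixed, the saturated chain carbon also matters: tert-butyl to propyl gives a 5.2-fold higher number from compound 2 to compound 4 (0.72 log units; beyond the scatter) while cyclobutyl to propyl gives a 1.3-fold higher number from compound 1 to compound 4 (0.10 log units; within the scatter) and leaves those two groups indistinguishable. Nothing available explains these differences.

From the compounds shown here alone, whether a nitrile or a chlorine atom at this ring carbon would give a lower number remains open, as does whether tert-butyl has the same effect alongside methyl.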